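Taking the chloro group off compound 3

A few compounds are considered here, and "the series" means these few. Any claim that something is new, unique, unknown or untested is made for them only; others in the source may bear on it.

Measured in a physicochemical assay for pharmacokinetics; on this read-out higher numbers stand for a longer-lived compound and lower numbers for a shorter-lived compound:
compound 1 `COc1cccc(CNC(=O)N2C(=O)c3ccccc3S2(=O)=O)c1`: > 166 h
compound 2 `O=C(NCc1ccc(C(F)(F)F)cc1)N1C(=O)c2ccccc2S1(=O)=O`: > 166 h
compound 3 `O=C(NCc1ccccc1Cl)N1C(=O)c2ccccc2S1(=O)=O`: > 166 h

Each of these readings is a limit of the assay and not a number.

Compound 3 stands at > 166 h, which is a limit. It shares this position with the rest of the series: the limit of > 166 h in this assay, at which 3 of the 3 values shown sit.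

Compound 4 `O=C(NCc1ccccc1)N1C(=O)c2ccccc2S1(=O)=O` carries hydrogen in place of chloro on an aromatic carbon, ortho to a large group: hydrogen in place of chloro on an aromatic carbon.

Among the measured compounds shown here, the one measured step that bears on this change, a step that the two limits leave unreadable from compound 1 to compound 3, has no readable size, so no measured step sets a scale. What remains is that all three measured compounds, with different groups on the phenyl ring, reach the same limit, and none goes against this. No step beyond the scatter is therefore expected in this assay, and the expected step is a step that the limit leaves unreadable from compound 3 to compound 4. The reading may well be a limit again.

Compound 4 is estimated at 200 h, with an expected range of 100 h to 400 h.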

Compound 4, half-life: > 166 h
Compound 4: only a limit was reported (the forecaster's own chance of this, stated with the estimate: 70%); the middle value does not contradict the limit.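

In this assay, no step can be read from compound 1, compound 2 or compound 3 to compound 4, and all four share one limit: the limit of > 166 h in this assay, at which 4 of the 4 values shown sit.

Still open is whether the half-lives of these compounds differ at all past that limit.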